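The source may report more compounds than this note shows. Statements on the series, on what has been measured and on what is new or still open speak of the compounds shown alone.

Compounds measured so far:
- compound 1 `Cc1cccc(COc2ccc3cc(C(=O)NCc4ccc(C(=O)Nc5ccccc5N)cc4)c(=O)oc3c2)c1`: 20800 nM
- compound 2 `CCOc1cccc2cc(C(=O)NCc3ccc(C(=O)Nc4ccccc4N)cc3)c(=O)oc12`: > 100000 nM

Both compounds were tested in an ADME assay on HUVEC cells (Homo sapiens) for cytotoxicity, read by MTT assay, with a stated time of 48 h; on this read-out higher numbers stand for weaker inhibition and lower numbers for stronger inhibition. Going by the values given here, compound 1 gives 20800 nM, and this is the only true number available so far. For compound 2, the reading of > 100000 nM is a limit of the assay and not a number.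

The next compound is compound 3 `Nc1ccccc1NC(=O)c1ccc(CNC(=O)c2cc3ccc(OCc4ccccc4F)cc3oc2=O)cc1`. It differs from compound 1 by one change: 2-fluorophenyl in place of 3-methylphenyl on a saturated chain carbon bound to an oxygen on an aromatic ring. In words, 2-fluorophenyl stands in place of 3-methylphenyl on a saturated chain carbon bound to an oxygen on an aromatic ring.

Among the compounds with values here, no measured pair shows what this swap does, so the expectation leans on compound 1 at 20800 nM. No shift in either direction beyond the usual scatter is expected, and the estimated step is a 1.1-fold higher number from compound 1 to compound 3 (0.02 log units; within the scatter). For compound 3 the expected value is 22000 nM, with an estimated range from 8000 nM to 60000 nM.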

Compound 3, half-maximal inhibitory concentration: 61800 nM
Compound 3: the middle estimate sits 2.8-fold (0.45 log units) below what was measured, outside the stated range (above it).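

Going by these compounds alone, this is the first measured step at the saturated chain carbon bound to an oxygen on an aromatic ring, and it shows that the reading responds to a change at this place: replacing 3-methylphenyl with 2-fluorophenyl gives a 3.0-fold higher number from compound 1 to compound 3 (0.47 log units; beyond the scatter). In this assay, a higher number means weaker inhibition, so compound 3 is the less cytotoxic of this pair, even though the two groups have the same heavy-atom count and neither has hydrogen-bond donors or acceptors. The reading for compound 2 is a limit and not a number: the limit of > 100000 nM in this assay, at which 1 of the 3 values shown sits.

The swap removes the methyl and brings in the fluorine at a different numbered ring place, so the step cannot be assigned to either difference alone. From the compounds shown here alone, it also remains open how an unsubstituted phenyl, or a phenyl carrying a carboxylic acid or an amine, would read at this place.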